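The source may report more compounds than this note shows. Statements on the series, on what has been measured and on what is new or still open speak of the compounds shown alone.

Of the compounds shown here, three built on one shared core have been measured in a functional assay on PANC-1 cells (Homo sapiens) for inhibition, read by MTT assay, with a stated time of 24 h, tested at 10 uM; a higher number here means more inhibition at the concentration tested (going by the name of the read-out), a lower number less inhibition. Compound 1 `CC(C)=CCOc1cc(=O)n(CCCO)c2c1CC(CC=C(C)C)C(C)(C)C2` gives 20.7%. Compound 2 `CC(C)=CCC1Cc2c(OCCCOc3ccc(Cl)cc3)cc(=O)n(CCCO)c2CC1(C)C` gives 22.7%. Between these two the step is a number 2 percentage points higher from compound 1 to compound 2 (within the scatter). Compound 3 `CC(C)=CCC1Cc2c(OC(=O)Nc3ccc(F)c(Cl)c3)cc(=O)n(CCCO)c2CC1(C)C` gives 79.8%, the highest of the three numbers. The steps of a number 59.1 percentage points higher from compound 1 to compound 3 (beyond the scatter) and a number 57.1 percentage points higher from compound 2 to compound 3 (beyond the scatter) both lie well beyond the scatter, so compound 3 stands clearly apart from the other two.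

Compound 4 `CC(C)=CCC1Cc2c(OC(=O)Nc3ccc(Cl)c(Cl)c3)cc(=O)n(CCCO)c2CC1(C)C` differs from compound 3 in one place: chloro in place of fluoro on an aromatic carbon. Among the compounds with values here, no measured step bears directly on this change. The two large steps that lead to compound 3 replaced the whole group on the ring oxygen with the carbamoyl group, and that group stays intact here; the small step between compound 1 and compound 2 touched a different part of the molecule. With no measured exchange of one halogen for another to draw on, a step within the scatter is expected in this assay, neither clearly up nor down. Compound 4 is therefore estimated at 78%, between 62% and 90%, which means an expected step of a number 1.8 percentage points lower from compound 3 to compound 4 (within the scatter).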

Compound 4, a percentage reported as inhibition, at one concentration (the size of the read-out at that concentration, not a potency): 61.4%
Compound 4: middle estimate off by 16.6 percentage points, on the high side; the measured number lies below the stated range.
By their numbers in this assay, from the lowest: compounds 1 and 2 (each within the scatter of the next); then compound 4; then compound 3.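

Exchanging fluoro for chloro on this ring, ortho to a chloro group and para to a large group, is not a neutral swap in this assay: this change of one heavy atom gives a number 18.4 percentage points lower from compound 3 to compound 4 (beyond the scatter) and so shows that the number responds to which halogen sits here. The carbamoyl group on the ring oxygen still keeps a clear lead with the 3,4-dichlorophenyl ring, with a number 38.7 percentage points higher from compound 2 to compound 4 (beyond the scatter) and a number 40.7 percentage points higher from compound 1 to compound 4 (beyond the scatter) so its advantage does not depend on fluoro. Nothing measured here explains why the number falls with this exchange.

The compounds shown leave open how this position behaves with hydrogen, a methoxy group or a trifluoromethyl group in place of the halogen. They also leave open whether the neighbouring chloro group is needed at all.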